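Acetyl to Furanoyl Amide: Expected Cytotoxicity of Compound 3

The source may hold more compounds than are shown below. What is called first, only, known or untested is meant among the compounds shown, and "the series" means these compounds.

Measured compounds and values in a functional assay on WI-38 VA13 cells (Homo sapiens) for cytotoxicity; a lower number here means that less compound is needed, a higher number that more compound is needed for the effect:
compound 1 `O=C(Nc1ccc2nc(NC(=O)C3CCCCC3)sc2c1)c1ccc(Br)cc1` — for compound 1 the assay gives only a limit, > 4 ug/mL
compound 2 `CC(=O)Nc1ccc2nc(NC(=O)C3CCCCC3)sc2c1` — compound 2 gives 2.7 ug/mL

Compound 2 holds the only actual number shown in this assay. Compound 1 returned only a limit of the assay, (the limit of > 4 ug/mL in this assay, at which 1 of the 2 values shown sits).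

Compound 3 `Cc1coc(C)c1C(=O)Nc1ccc2nc(NC(=O)C3CCCCC3)sc2c1` differs from compound 2 in one place: 2,4-dimethylfuran-3-yl in place of methyl on a carbonyl carbon. Among the measured steps, only an at least 1.4-fold lower number from compound 1 to compound 2 (0.17 log units; that floor lies within the scatter) bears on this change, as it also exchanges a methyl against an aromatic group on the same carbonyl carbon, there in the opposite direction. Its size stays within the usual scatter, so it gives only a weak hint that an aromatic group at this position raises the number. Compound 3 is therefore expected to sit slightly higher than compound 2, with a fair chance that only a limit is reported. The expected step is a 1.5-fold higher number from compound 2 to compound 3 (0.17 log units; within the scatter). Compound 3 is estimated at 4 ug/mL, with a range from 2 ug/mL to 8 ug/mL.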

Compound 3, half-maximal effective concentration: 2.7 ug/mL
Estimate against measurement, compound 3: 1.5-fold (0.17 log units) above, within the range that was stated.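

In this assay, putting 2,4-dimethylfuran-3-yl in place of methyl on the carbonyl carbon gives no change at the digits printed from compound 2 to compound 3 (within the scatter), so this position accepts a much larger group, with a five-membered aromatic ring, without a readable shift in the number. Among the compounds shown here, the earlier pair could not show this, as its only aromatic member gave no actual number; compound 3 now supplies an actual number for an aromatic group on this carbonyl carbon, and the weak hint from that pair finds no support here. Exchanging 4-bromophenyl for the furan gives an at least 1.4-fold lower number from compound 1 to compound 3 (0.17 log units; that floor lies within the scatter), a floor that lies within the scatter and does not separate the two aromatic groups, and the value for compound 1 is a limit and not a number: the limit of > 4 ug/mL in this assay, at which 1 of the 3 values shown sits.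

As far as these compounds go, how far compound 1 really lies from compound 2 and compound 3 therefore stays open, and with it whether 4-bromophenyl differs from the other two groups at all. Also open, from the compounds shown here alone, is whether an amine, a carboxylic acid or a longer alkyl chain on this carbonyl carbon would move the number beyond the scatter.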